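This account rests on a few compounds, and the source may have more. Where it says the series, first, only, none or still open, it means among the compounds named here.

Measured so far:
compound 1 `O=C(Nc1cccc(N2CCCC2=O)c1)C1CCCN(C(=O)c2cc(C(F)(F)F)cc(C(F)(F)F)c2)C1` — 0%
compound 2 `Cc1cccc(C(=O)N2CCCC(C(=O)Nc3ccc(Cl)cc3)C2)c1` — 0%

In an ADME assay on PC-3 cells (Homo sapiens) for cytotoxicity, read by WST assay, tested at 100 uM (a lower number here means less inhibition, a higher number more inhibition at the concentration tested (going by the name of the read-out)), compound 1 gives 0%. Compound 2 gives 0% in this assay. Compound 1 therefore stands level with compound 2, its nearest neighbour, with no change at the digits shown. Compound 3 `O=C(Nc1cccc(CN2CCCC2)c1)C1CCCN(C(=O)c2cc(C(F)(F)F)cc(C(F)(F)F)c2)C1` is not yet measured; it differs from compound 1 by (pyrrolidin-1-yl)methyl in place of 2-oxopyrrolidin-1-yl on an aromatic carbon. Within the data shown here, no step between measured compounds covers this change, so no measured pair sets its size. The step of a number 5 percentage points higher from compound 1 to compound 3 (within the scatter) is expected to stay within the scatter, with no clear direction. For compound 3 the expected value is 5%, in a range from 0% to 25%.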

Compound 3, a percentage reported as inhibition, at one concentration (the size of the read-out at that concentration, not a potency): 51%
Compound 3: middle estimate off by 46 percentage points, on the low side; the whole stated range lies below it.
By their numbers in this assay, from the lowest: compounds 1 and 2 (each within the scatter of the next); then compound 3.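

In this assay, (pyrrolidin-1-yl)methyl in place of 2-oxopyrrolidin-1-yl on this aromatic carbon gives a number 51 percentage points higher from compound 1 to compound 3 (beyond the scatter), so the position is sensitive to this change. The two groups have the same heavy-atom count and each holds one five-membered ring, yet only the first has a carbonyl and only the second a methylene link. No measurement here gives the reason for the step. Which of those differences carries the step stays open. A pyrrolidin-1-yl group placed directly on the aromatic ring, or an open-chain dimethylaminomethyl group, would help separate them.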